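The compounds below may be only part of what the source reports. "The series", "measured", "known", "first", "only" and "open" are said of these compounds alone.

Measured so far:
compound 1 `Cn1cc(C2=C(c3nn(CCCn4cncn4)c4ncccc34)C(=O)N(c3ccccc3)C2=O)c2ccccc21` — > 100000 nM
compound 2 `Cn1cc(C2=C(c3nn(CCCn4ccnc4)c4ncccc34)C(=O)N(c3ccccc3)C2=O)c2ccccc21` — 5510 nM

In a functional assay on K562 cells (Homo sapiens) for antiproliferative activity, read by MTT assay, with a stated time of 48 h (on this read-out higher numbers stand for weaker inhibition and lower numbers for stronger inhibition), compound 1 gives only a limit, > 100000 nM (the limit of > 100000 nM in this assay, at which 1 of the 2 values shown sits). In this assay compound 2 gives 5510 nM, which is the only actual number shown, so compound 2 stands alone. Compound 3 `Cn1cc(C2=C(c3nn(CCCn4cccc4)c4ncccc34)C(=O)N(c3ccccc3)C2=O)c2ccccc21` has not been measured. It differs from compound 2 by 1H-pyrrol-1-yl in place of 1H-imidazol-1-yl on a saturated chain carbon, three bonds along the chain from an aromatic nitrogen. For the measured compounds named here, the one measured step at the same place is an at least 18-fold lower number from compound 1 to compound 2 (1.25 log units; beyond the scatter); that step and the present one are changes of the same kind, in the hetero atom content of the five-membered aromatic ring on the chain. From the compounds shown here alone, a move in the same direction is expected, but the earlier step rests on a limit and its true size is unknown, so the expectation is held loosely. Compound 3 is therefore estimated to give 3000 nM in this assay, within 700 nM to 15000 nM, an expected step of a 1.8-fold lower number from compound 2 to compound 3 (0.26 log units; within the scatter).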

Compound 3, half-maximal inhibitory concentration: 36600 nM
Estimate against measurement, compound 3: 12-fold (1.09 log units) below; the whole stated range lies below it.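

In this assay, the change at this place, on a saturated chain carbon, three bonds along the chain from an aromatic nitrogen, gives a 6.6-fold higher number from compound 2 to compound 3 (0.82 log units; beyond the scatter), so 1H-imidazol-1-yl now stands as the strongest of the three rings shown, with compound 2 the only one of the three in the low range of numbers. Against 1H-1,2,4-triazol-1-yl, 1H-pyrrol-1-yl still gives an at least 2.7-fold lower number from compound 1 to compound 3 (0.43 log units; beyond the scatter), so the two ring changes away from 1H-imidazol-1-yl both raise the number, and the order does not follow a simple run in ring nitrogen content. Compound 1 gives only a limit, so its place in that order has no upper end: the limit of > 100000 nM in this assay, at which 1 of the 3 values shown sits.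

The compounds shown leave open whether a dimethylamino or morpholine group at the chain end would match 1H-imidazol-1-yl. They also leave open how 1H-imidazol-1-yl behaves on a chain shorter or longer than 3-(1H-imidazol-1-yl)propyl.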